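The compounds below may be only part of what the source reports. "The series", "measured", "known", "first", "only" and "open" are said of these compounds alone.

Working notes on the series. Compound 3 `CCCSc1nc(N/N=C(\C)c2ccccc2O)c2nnn(Cc3ccccc3)c2n1` carries an unsubstituted benzyl group on the shared core. In a functional assay on MGC-803 cells (Homo sapiens) for antiproliferative activity, read by MTT assay, with a stated time of 72 h (a lower number here means a stronger inhibitor, a higher number a weaker inhibitor), compound 3 gives 2310 nM, the lowest of the three numbers recorded so far. Compound 1 `CCCSc1nc(N/N=C(\C)c2ccccc2O)c2nnn(Cc3ccccc3Cl)c2n1`, with a 2-chlorobenzyl group, gives 35000 nM in this assay, and compound 2 `CCCSc1nc(N/N=C(\C)c2ccccc2O)c2nnn(Cc3ccc(F)cc3)c2n1`, with a 4-fluorobenzyl group, gives 11000 nM. Both halogenated members stand well above compound 3: a 15-fold lower number from compound 1 to compound 3 (1.18 log units; beyond the scatter) and a 4.8-fold lower number from compound 2 to compound 3 (0.68 log units; beyond the scatter). The two halogenated members also differ from each other, by a 3.2-fold lower number from compound 1 to compound 2 (0.50 log units; beyond the scatter).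

Compound 4 `CCCSc1nc(N/N=C(\C)c2ccccc2O)c2nnn(Cc3cccc(Cl)c3)c2n1` is the next step from compound 3: chloro in place of hydrogen on an aromatic carbon, so benzyl becomes 3-chlorobenzyl. For the measured compounds named here, no measured pair places a chloro at this position. The two halogen removals recorded, from compound 1 and from compound 2, each lowered the number beyond the scatter, the larger of the two being the one involving chloro. Putting a chloro back onto the ring is therefore expected to raise the number in this assay, though the untested position leaves the size open. Compound 4 is expected to show a 4.3-fold higher number from compound 3 to compound 4 (0.64 log units; beyond the scatter) in this assay. The estimate for compound 4 is 10000 nM, within 3000 nM to 35000 nM.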

Compound 4, half-maximal inhibitory concentration: 6500 nM
Estimate against measurement, compound 4: 1.5-fold (0.19 log units) above, within the range that was stated.
By their numbers in this assay, from the lowest: compound 3; then compounds 4 and 2 (each within the scatter of the next); then compound 1.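

With a chloro on the aromatic carbon meta to a large group, the number rises again, a 2.8-fold higher number from compound 3 to compound 4 (0.45 log units; beyond the scatter), in this assay, so all three halogenated benzyl members now stand above the unsubstituted benzyl of compound 3. For the compounds shown here, the two chlorobenzyl members also give the first comparison of one halogen at two ring positions, and the place of the chloro matters, a 5.4-fold lower number from compound 1 to compound 4 (0.73 log units; beyond the scatter), whereas 3-chlorobenzyl and 4-fluorobenzyl are not separated, a 1.7-fold lower number from compound 2 to compound 4 (0.23 log units; within the scatter). Nothing on hand explains either the rise or the dependence on position.

Across these four compounds, each halogen on the benzyl ring goes with a higher number than hydrogen, but the series cannot separate the identity of the halogen from its position, since fluoro and chloro share no ring position here. From the compounds shown here alone, it also remains open whether a methoxy group, an amine or a carboxylic acid on the same aromatic carbon would raise the number as chloro does, or bring it below that of compound 3.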